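From vinyl to but-1-en-1-yl on a shared core

The compounds below may be only part of what the source reports. "The series", "measured", "known", "first", "only" and "open" are said of these compounds alone.

Of the compounds shown here, three built on one shared core have been measured so far: compound 1 (`CCCCN1C(=O)[C@@H](C)NC(=O)[C@@H]2Cc3ccc(OC)c(c3)Oc3ccc(cc3)C[C@@H](C(=O)N2C)N(C)C(=O)[C@H](C)NC(=O)[C@H](Cc2ccc(OC)cc2)N(C)C(=O)[C@@H]1C`), compound 2 (`CCCCCN1C(=O)[C@@H](C)NC(=O)[C@@H]2Cc3ccc(OC)c(c3)Oc3ccc(cc3)C[C@@H](C(=O)N2C)N(C)C(=O)[C@H](C)NC(=O)[C@H](Cc2ccc(OC)cc2)N(C)C(=O)[C@@H]1C`) and compound 3 (`C=CCN1C(=O)[C@@H](C)NC(=O)[C@@H]2Cc3ccc(OC)c(c3)Oc3ccc(cc3)C[C@@H](C(=O)N2C)N(C)C(=O)[C@H](C)NC(=O)[C@H](Cc2ccc(OC)cc2)N(C)C(=O)[C@@H]1C`). In a functional assay on P388 cells (Mus musculus) for cytotoxicity (on this read-out higher numbers stand for weaker inhibition and lower numbers for stronger inhibition), compound 1 gives 12 nM, compound 2 gives 21.4 nM and compound 3 gives 18.6 nM. Compound 3 therefore stands within the scatter of both other compounds, and the numbers do not rank the three.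

Compound 4 (`CC/C=C/CN1C(=O)[C@@H](C)NC(=O)[C@@H]2Cc3ccc(OC)c(c3)Oc3ccc(cc3)C[C@@H](C(=O)N2C)N(C)C(=O)[C@H](C)NC(=O)[C@H](Cc2ccc(OC)cc2)N(C)C(=O)[C@@H]1C`) carries but-1-en-1-yl in place of vinyl on a saturated chain carbon bound to an amide-type nitrogen in a ring.

Within the data shown here, three measured steps bear on this change. Methyl in place of hydrogen on the saturated chain gave a 1.8-fold higher number from compound 1 to compound 2 (0.25 log units; within the scatter). Vinyl in place of propyl gave a 1.6-fold higher number from compound 1 to compound 3 (0.19 log units; within the scatter), and vinyl in place of butyl gave a 1.2-fold lower number from compound 2 to compound 3 (0.06 log units; within the scatter). Among the measured compounds shown here, none of these steps leaves the scatter, although no measured compound yet combines a double bond with a chain as long as that of compound 4. No step beyond the scatter is therefore expected in this assay, and no direction can be favoured. The expected step is a 1.1-fold higher number from compound 3 to compound 4 (0.03 log units; within the scatter). For compound 4 the estimated value is 20 nM, with an expected range of 9 nM to 45 nM.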

Compound 4, half-maximal inhibitory concentration: 12 nM
The estimate for compound 4 lay 1.7-fold (0.22 log units) above the measured number; the measured number falls inside the stated range.
By their numbers in this assay, from the lowest: compounds 1, 4, 3 and 2 (each within the scatter of the next).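

In this assay, among these compounds, but-1-en-1-yl in place of vinyl, on a saturated chain carbon bound to an amide-type nitrogen in a ring, gives a 1.6-fold lower number from compound 3 to compound 4 (0.19 log units; within the scatter) and thereby supplies the first reading of a double bond together with the larger chain. Compared with the saturated chains, but-1-en-1-yl in place of butyl gives a 1.8-fold lower number from compound 2 to compound 4 (0.25 log units; within the scatter) while but-1-en-1-yl in place of propyl gives no change at the digits printed from compound 1 to compound 4 (within the scatter) and so leaves the printed numbers identical. At this position, then, neither adding carbons to the vinyl group nor placing a double bond in a chain of this size carries compound 4 beyond the scatter of any of the three earlier compounds, and the four compounds still cannot be ranked.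

The compounds shown offer nothing that could explain how closely these numbers lie. Going by these compounds, it remains open whether a longer chain, a terminal amine, a carboxylic acid or a phenyl group at this position would give a step beyond the scatter, since every group seen here is a small unsubstituted hydrocarbon chain.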